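Swapping fluoro for bromo on the benzyl ring

A few compounds are considered here, and "the series" means these few. Any claim that something is new, unique, unknown or untested is made for them only; others in the source may bear on it.

Measured so far in an assay on isolated protein for inhibition of Amine oxidase [flavin-containing] B (Homo sapiens), read by fluorescence, with stated times of 15 min and 20 min; a lower number here means a stronger inhibitor, a higher number a weaker inhibitor:
- compound 1, `CC(C)(C)c1cc(/C=C/C(=O)NC2CCN(Cc3ccccc3)CC2)cc(C(C)(C)C)c1O`: 33500 nM
- compound 2, `CC(C)(C)c1cc(/C=C/C(=O)NCCC2CCN(Cc3cccc(F)c3)CC2)cc(C(C)(C)C)c1O`: 6500 nM
- compound 3, `CC(C)(C)c1cc(/C=C/C(=O)NCCC2CCN(Cc3ccc(F)cc3)CC2)cc(C(C)(C)C)c1O`: 11100 nM

Of the three numbers, compound 3 has the second highest. Its nearest neighbour is compound 2, and the step of a 1.7-fold higher number from compound 2 to compound 3 (0.23 log units; within the scatter) lies within the usual scatter, so the two cannot be told apart. Compound 1, which lacks the two-carbon chain between the amide nitrogen and the ring and carries an unsubstituted benzyl group, gives a clearly higher number than compound 3, a gap beyond the scatter.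

Compound 4, `CC(C)(C)c1cc(/C=C/C(=O)NCCC2CCN(Cc3ccc(Br)cc3)CC2)cc(C(C)(C)C)c1O`, differs from compound 3 in one place: bromo in place of fluoro on an aromatic carbon. For the measured compounds named here, none of the measured steps changes a halogen for another halogen; the only single-point step, from compound 2 to compound 3, moves a fluoro from one position to another and stays within the scatter. There is therefore nothing to point to a move in either direction, and the expectation is a step of about a 1.2-fold lower number from compound 3 to compound 4 (0.09 log units; within the scatter), that is no change beyond the scatter. Compound 4 is expected to give roughly 9000 nM in this assay, with a plausible range from 3000 nM to 27000 nM.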

Compound 4, half-maximal inhibitory concentration: 13200 nM
Estimate against measurement, compound 4: 1.5-fold (0.17 log units) below; the range from low to high includes it.
By their numbers in this assay, from the lowest: compounds 2, 3 and 4 (each within the scatter of the next, the first and the last beyond it); then compound 1.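

In this assay, exchanging 4-fluorobenzyl for 4-bromobenzyl gives a 1.2-fold higher number from compound 3 to compound 4 (0.08 log units; within the scatter), so this first halogen-for-halogen exchange in the set leaves no difference that can be read at this ring carbon. Set against the 3-fluorophenyl analogue, the same bromo compound gives a 2.0-fold higher number from compound 2 to compound 4 (0.31 log units; beyond the scatter), which is the only gap among these three halogenated compounds to pass the scatter, and it does so modestly; since that step changes both the halogen and its place on the ring, it cannot be assigned to either change alone. Nothing available here explains why the fluoro-to-bromo exchange makes so little difference.

The compounds shown leave open whether a 3-bromobenzyl group would separate the effect of the halogen from that of its place on the ring. They also leave open whether this carbon accepts groups of a different kind, such as a methoxy or a nitrile, and how a plain benzyl group would compare on the longer chain of compound 3, since compound 1 carries it on a shorter link.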